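A Chlorine Added to the Anilino Ring of Compound 3

The source may report more compounds than this note shows. Statements on the series, on what has been measured and on what is new or still open speak of the compounds shown alone.

Compound 1 `COC(=O)CN(C)c1nc(Nc2ccc(Cl)cc2)ncc1[N+](=O)[O-]` — 23500 nM in a functional assay on A549 cells (Homo sapiens) for antiproliferative activity, read by MTT assay, with a stated time of 48 h; on this read-out higher numbers stand for weaker inhibition and lower numbers for stronger inhibition
Compound 2 `COC(=O)CN(C)c1nc(NCc2ccccc2)ncc1[N+](=O)[O-]` — 79400 nM
Compound 3 `CCOC(=O)CNc1nc(Nc2ccccc2)ncc1[N+](=O)[O-]` — > 100000 nM, which is a limit of the assay

Three compounds share one core and were measured in this assay. Compound 1 gives 23500 nM, and compound 2 gives 79400 nM. For the measured compounds named here, the only single-point step among them is a 3.4-fold higher number from compound 1 to compound 2 (0.53 log units; beyond the scatter), a modest weakening. Compound 3 stands apart: it reports only > 100000 nM, a limit rather than a number, the line described as the limit of > 100000 nM in this assay, at which 1 of the 3 values shown sits.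

Compound 4 `CCOC(=O)CNc1nc(Nc2ccc(Cl)cc2)ncc1[N+](=O)[O-]` differs from compound 3 by chloro in place of hydrogen on an aromatic carbon. Going by the values given here, no measured step exchanges hydrogen for chloro directly. The closest evidence is the step from 4-chlorophenyl to benzyl, which bears on this change only at one remove, since it alters the ring attachment as well as the chloro. Its modest size suggests that the chloro contributes something, but compound 3 sits at a limit, so the starting point itself is uncertain. Compound 4 is therefore expected to show a somewhat lower number than the limit of compound 3, estimated at 60000 nM with a range from 25000 nM to 150000 nM, which amounts to an at least 1.6-fold lower number from compound 3 to compound 4 (0.22 log units; that floor lies within the scatter).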

Compound 4, half-maximal inhibitory concentration: > 100000 nM
Compound 4: only a limit was reported; the forecaster's own chance of this, stated with the estimate: 35%; middle value at least 1.6-fold (0.22 log units) away from the limit.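

In this assay compound 4 gives > 100000 nM, which is a limit of the assay, and the step from compound 3 cannot be read, since both compounds sit at that limit: the limit of > 100000 nM in this assay, at which 2 of the 4 values shown sit. The chloro on the anilino ring therefore does not bring this compound to a measurable number, and nothing can be said about whether it has any effect at all on the ring of compound 3. For the compounds shown here, with the 4-chlorophenyl group held fixed, ((ethoxycarbonyl)methyl)amino in place of ((methoxycarbonyl)methyl)(methyl)amino gives an at least 4.2-fold higher number from compound 1 to compound 4 (0.62 log units; beyond the scatter), which shows, as the earlier compounds could not, that in this pair the group on the other aromatic carbon decides whether a number can be read.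

That step changes both the ester and the methyl on the nitrogen at once, and the compounds shown do not separate the two. Also open, as far as these compounds go, is how a carboxylic acid in place of the ester, or a bromo or methoxy group in place of the chloro, would read in this assay.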